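A few compounds are considered here, and "the series" means these few. Any claim that something is new, unique, unknown or untested is made for them only; others in the source may bear on it.

In a functional assay for inhibition, with Homo sapiens as the target (a lower number here means tighter binding, a higher number weaker binding), the measured compounds are:
- Compound 1 `N#Cc1ccc(C2OCC(C/C=C\CCC(=O)O)C(c3cccnc3)O2)cc1`: 1290 nM
- Compound 2 `O=C(O)CC/C=C\CC1COC(c2ccc(C(F)(F)F)cc2)OC1c1cccnc1`: 1780 nM
- Compound 3 `Cc1ccc(C#N)c(OC(C)(C)C2OCC(C/C=C\CCC(=O)O)C(c3cccnc3)O2)c1`: 15.9 nM

Compound 3, at 15.9 nM, has the lowest number of the three, well under compound 1 at 1290 nM and compound 2 at 1780 nM. Compound 4 `CC(C)(Oc1ccc(F)cc1)C1OCC(C/C=C\CCC(=O)O)C(c2cccnc2)O1` differs from it in one place, 4-fluorophenyl in place of 2-cyano-5-methylphenyl on an oxygen on a saturated carbon. Among the measured compounds shown here, only one measured step exists, a 1.4-fold higher number from compound 1 to compound 2 (0.14 log units; within the scatter), which is within the scatter. It swaps trifluoromethyl for cyano, a different change, so it offers little guidance here. For the measured compounds named here, no measured compound carries the entering group. With compound 3 already at 15.9 nM, a moderate move to a higher number, beyond the scatter, is expected: an estimated 5.7-fold higher number from compound 3 to compound 4 (0.75 log units; beyond the scatter). Compound 4 is expected at 90 nM, with an estimated range of 20 nM to 400 nM.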

Compound 4, dissociation constant: 120 nM
Estimate against measurement, compound 4: 1.3-fold (0.12 log units) below; measured number inside the range.
By their numbers in this assay, from the lowest: compound 3; then compound 4; then compounds 1 and 2 (each within the scatter of the next).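

In this assay, 4-fluorophenyl in place of 2-cyano-5-methylphenyl on the oxygen gives a 7.5-fold higher number from compound 3 to compound 4 (0.88 log units; beyond the scatter), so the number does respond to the aromatic group at this place. The group leaving has 9 heavy atoms and one hydrogen-bond acceptor, the group entering 7 and none, so several features change in this single step. Nothing available explains the size of the step. Still open, from the compounds shown here alone, is whether the nitrile or the methyl alone accounts for it, and what an amine on that ring would give.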